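This account rests on a few compounds, and the source may have more. Where it says the series, first, only, none or still open, it means among the compounds named here.

Measured compounds:
compound 1, `Nc1ccn(C/C=C/CCl)c(=O)n1`, 50000 nM
compound 2, `Nc1ccn(C/C=C/CO)c(=O)n1`, > 550000 nM
compound 3, `Nc1ncnc2c1ncn2CC#CCCl`, 90000 nM

In a functional assay on L1210 cells (Mus musculus) for inhibition (on this read-out higher numbers stand for weaker inhibition and lower numbers for stronger inhibition), compound 1 gives 50000 nM. For compound 2 the value in this assay is a limit, > 550000 nM, not a number; the change from compound 1 to compound 2 is hydroxy in place of chloro on a saturated chain carbon bound to a double-bonded chain carbon, and it brought an at least 11-fold higher number from compound 1 to compound 2 (1.04 log units; beyond the scatter), the second value sitting at the limit of > 550000 nM in this assay, at which 1 of the 3 values shown sits. Compound 3 has a different core; how its core differs from that of compound 1 is not broken down here. In this assay compound 3 gives 90000 nM, which lies within the usual scatter of the value of compound 1.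

Compound 4, `Nc1ncnc2c1ncn2CC#CCO`, has not yet been measured in this assay. Its difference from compound 3 is hydroxy in place of chloro on a saturated chain carbon bound to a triple-bonded carbon. This is the same kind of change as that from compound 1 to compound 2, but the surroundings differ: there the hydroxy enters on a saturated chain carbon bound to a double-bonded chain carbon, here on a saturated chain carbon bound to a triple-bonded carbon. For the measured compounds named here, on the strength of the single earlier step, compound 4 is expected to show a large loss, estimated as an 8.9-fold higher number from compound 3 to compound 4 (0.95 log units; beyond the scatter), because compound 2 reached only (the limit of > 550000 nM in this assay, at which 1 of the 3 values shown sits). The estimate for compound 4 in this assay is 800000 nM, within a range from 200000 nM to 3000000 nM, and it is expected that the assay may again report only a limit.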

Compound 4, half-maximal inhibitory concentration: 490000 nM
For compound 4 the middle estimate is 1.6-fold (0.21 log units) above the measured one; low and high end bracket the measured number.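

In this assay, hydroxy in place of chloro on a saturated chain carbon bound to a triple-bonded carbon gave a 5.4-fold higher number from compound 3 to compound 4 (0.74 log units; beyond the scatter), so the weakening seen with the same change on the core of compound 1 appears again, in the same direction, on a second core. This is a modest step, and it shows that the direction held in both pairs; it does not show that the change would act the same way on any further core, and since the two pairs differ in their chain as well as in their core, they cannot separate the one from the other: the same change on two cores in this assay, an at least 11-fold higher number (1.04 log units; beyond the scatter) from compound 1 to compound 2 and a 5.4-fold higher number (0.74 log units; beyond the scatter) from compound 3 to compound 4; the limit leaves it open whether they differ Compound 2 is recorded only as a limit, not a number, so the full size of the first step stays unknown and no gap between the two steps can be stated: the limit of > 550000 nM in this assay, at which 1 of the 4 values shown sits.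

The compounds shown leave open whether the weakening is specific to hydroxy, since a methoxy group, an amine or a bromo group at the same place would each test how far chloro itself matters. They also leave open how the change behaves on a longer chain, and whether the core of compound 3 would give a step of similar size with a double-bonded chain in place of the triple-bonded one.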